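A methyl group added to compound 2

The source may report more compounds than this note shows. Statements on the series, on what has been measured and on what is new or still open speak of the compounds shown alone.

Measured so far in a functional assay on K562 cells (Homo sapiens) for antiproliferative activity, read by trypan blue exclusion, with a stated time of 48 h, tested at 10 uM; a higher number here means more inhibition of growth at the concentration tested, a lower number less inhibition of growth:
- compound 1 `Cc1ccc(/C=C/C(=O)Nc2ccc(Cl)cc2C(N)=O)cc1` gives 64% of inhibition
- compound 2 `NC(=O)c1cc(I)ccc1NC(=O)/C=C/c1ccccc1` gives 74.5% of inhibition

Compound 2 holds the higher of these two numbers, and its gap to compound 1 lies beyond the usual scatter of repeated measurements. Among the measured compounds shown here, no two measured compounds differ in only one place, so no single change has yet been measured on its own.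

Compound 3 `Cc1ccc(/C=C/C(=O)Nc2ccc(I)cc2C(N)=O)cc1` has not been measured. It differs from compound 2 in one place: methyl in place of hydrogen on an aromatic carbon (methyl in place of hydrogen on an aromatic carbon, turning phenyl into 4-methylphenyl). Compound 1 also carries this methyl group and still gives 64% in this assay, so a large loss seems unlikely. The expected a number 2.5 percentage points lower from compound 2 to compound 3 (within the scatter) is small and slightly downward, within the scatter. The estimate for compound 3 is 72% with a range of 58% to 86% expected.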

Compound 3, percent growth inhibition at one concentration: 26.3%
Compound 3: the middle estimate sits 45.7 percentage points above what was measured, outside the stated range (below it).
By their numbers in this assay, from the lowest: compound 3; then compound 1; then compound 2.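

On the iodo compound, a single methyl group turning phenyl into 4-methylphenyl brings a number 48.2 percentage points lower from compound 2 to compound 3 (beyond the scatter) in this assay, so this position is far from indifferent to even one added carbon. With that methyl in place, iodo in place of chloro brings a number 37.7 percentage points lower from compound 1 to compound 3 (beyond the scatter) in the same assay, so the halogen also matters, and the good value of compound 1 does not carry over to its iodo counterpart. Nothing measured here explains either drop.

The compounds shown leave open whether the methyl costs as much when chloro replaces iodo, since only the iodo pair isolates this change. They also leave open how a fluoro, a methoxy or an amine at the same position would read in this assay, and whether any of these would keep the value of compound 2.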